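Moving the Chlorine: From Compound 2 to Compound 3

The compounds below may be only part of what the source reports. "The series", "measured", "known", "first", "only" and "open" are said of these compounds alone.

Measured so far:
compound 1 `Cc1n[nH]c2ccc(-c3nc4cnc(N5CCN(C)CC5)cn4c3Nc3cccc(F)c3)cc12` — 18.5%
compound 2 `Cc1n[nH]c2ccc(-c3nc4cnc(N5CCN(C)CC5)cn4c3Nc3cccc(Cl)c3)cc12` — 0%

In a functional assay on MV4-11 cells (Homo sapiens) for inhibition, with a stated time of 120 h, tested at 10 uM (a lower number here means less inhibition, a higher number more inhibition at the concentration tested (going by the name of the read-out)), compound 2 gives 0%, the lowest of the two numbers. Compound 1 gives 18.5% in this assay, the step being a number 18.5 percentage points lower from compound 1 to compound 2 (beyond the scatter). Compound 3 `Cc1n[nH]c2ccc(-c3nc4cnc(N5CCN(C)CC5)cn4c3Nc3ccc(Cl)cc3)cc12` differs from compound 2 in one place: 4-chlorophenyl in place of 3-chlorophenyl on a nitrogen on an aromatic ring. Among the measured compounds shown here, the only measured step, a number 18.5 percentage points lower from compound 1 to compound 2 (beyond the scatter), swaps the halogen rather than its position, so it bears only loosely on this change. Compound 2 sits at the floor, so any expected step can only be upward or none beyond the scatter. Compound 3 is estimated at 10% (range 0% to 35%), an expected step of a number 10 percentage points higher from compound 2 to compound 3 (within the scatter).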

Compound 3, a percentage reported as inhibition, at one concentration (the size of the read-out at that concentration, not a potency): 83.7%
The estimate for compound 3 lay 73.7 percentage points below the measured number; the measured number lies above the stated range.
By their numbers in this assay, from the lowest: compound 2; then compound 1; then compound 3.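

In this assay, the change to 4-chlorophenyl gives a number 83.7 percentage points higher from compound 2 to compound 3 (beyond the scatter), so at this position the place of the chlorine on the ring matters far more than the earlier swap of halogen suggested. The comparison with the fluoro compound gives a number 65.2 percentage points higher from compound 1 to compound 3 (beyond the scatter), which puts compound 3 above both earlier compounds. Nothing available explains this shift. On these data alone, whether 4-fluorophenyl or 4-methoxyphenyl on the same nitrogen would match compound 3 stays open. So does how compound 3 behaves at other concentrations, since only one concentration is shown.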